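This account rests on a few compounds, and the source may have more. Where it says the series, first, only, none or still open, it means among the compounds named here.

Compound 1 has the structure `O=C1c2ccccc2NS(=O)(=O)N1COCCO`. In a functional assay on CCRF-CEM cells (Homo sapiens) for cytotoxicity (on this read-out lower numbers stand for higher toxicity in this test and higher numbers for lower toxicity in this test), compound 1 gives > 200 ug/mL, which is a limit of the assay rather than a measured number. Compound 2, with the structure `CCCOCN1c2ccccc2C(=O)NS1(=O)=O`, gives > 200 ug/mL in this assay, again a limit. Compound 3, with the structure `O=C1NS(=O)(=O)N(COCc2ccccc2)c2ccccc21`, gives > 200 ug/mL in this assay, also a limit. Among the compounds with values here, the one measured step, a step that the two limits leave unreadable from compound 2 to compound 3, cannot be read because the limit of > 200 ug/mL in this assay, at which 3 of the 3 values shown sit, leaves no room for a number on either side.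

Compound 4 has the structure `C#CCOCN1C(=O)c2ccccc2NS1(=O)=O`. It differs from compound 1 by ethynyl in place of hydroxymethyl on a saturated chain carbon bound to an oxygen on a saturated carbon. Within the data shown here, no measured step reports a readable size, so no step bears on this change with a number; the only comparison available shows that every compound so far sits at the limit. Compound 4 is therefore expected to stay at that limit as well, with an estimated value of 300 ug/mL and an expected range from 200 ug/mL to 500 ug/mL. The expected step in this assay is a step that the limit leaves unreadable from compound 1 to compound 4, that is, no change beyond the scatter.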

Compound 4, half-maximal cytotoxic concentration: > 200 ug/mL
Compound 4: no number, only a limit; the forecaster's own chance of this, stated with the estimate: 85%; the middle value is on the limit's open side.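

The step between compound 1 and compound 4 cannot be read, because both compounds stop at a limit rather than a number: the limit of > 200 ug/mL in this assay, at which 4 of the 4 values shown sit.

The compounds shown leave open how far past that limit each one lies, and whether any change to the side chain on the shared core would give a readable number in this assay.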